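The compounds below may be only part of what the source reports. "The series", "measured", "known", "first", "only" and "open" are said of these compounds alone.

Three ethyl esters carrying a 1H-pyrrol-2-yl group at the end of a double-bonded chain were tested first. In a functional assay on CCRF-CEM cells (Homo sapiens) for cytotoxicity, with a stated time of 72 h (a higher number here means a weaker inhibitor, a lower number a stronger inhibitor), compound 1 `CCOC(=O)/C=C/C=C/C=C/c1ccc[nH]1` gives 3670 nM, compound 2 `CCOC(=O)/C=C/C=C/C=C/C=C/c1ccc[nH]1` gives 1340 nM and compound 3 `CCOC(=O)/C=C/C=C/C=C/C=C/C=C/c1ccc[nH]1` gives 450 nM. Across these three compounds, the number falls as the chain gets longer, and no compound goes against this. Compound 2 therefore stands in the middle, and its gaps to compound 1 and compound 3 both lie beyond the scatter.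

Compound 4 `CCOC(=O)/C=C/C=C/C=C/C=C/c1nccs1` has not yet been measured. It keeps the chain of compound 2 and differs in one place: 1,3-thiazol-2-yl in place of 1H-pyrrol-2-yl on a double-bonded chain carbon bound to a double-bonded chain carbon. Here 1,3-thiazol-2-yl stands in place of 1H-pyrrol-2-yl on a double-bonded chain carbon bound to a double-bonded chain carbon. Going by the values given here, no measured pair shows what such a ring exchange does, so the expectation starts from compound 2 at 1340 nM and stays uncertain. A modest move toward weaker inhibition is expected, with an estimated 2.1-fold higher number from compound 2 to compound 4 (0.32 log units; beyond the scatter). For compound 4 the estimated value is 2800 nM, with an expected range of 900 nM to 9000 nM.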

Compound 4, half-maximal inhibitory concentration: > 10000 nM
Compound 4: a limit, no number; the forecaster's own chance of this, stated with the estimate: 8%; at least 3.5-fold (0.55 log units) between middle value and limit.
By their numbers in this assay, from the lowest: compound 3; then compound 2; then compound 1. At a limit, above all of these: compound 4.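

The three earlier compounds changed only the chain and kept 1H-pyrrol-2-yl throughout, so compound 4 gives the first view of the ring itself: 1,3-thiazol-2-yl in place of 1H-pyrrol-2-yl on the chain of compound 2 gives an at least 7.4-fold higher number from compound 2 to compound 4 (0.87 log units; beyond the scatter). The reading for compound 4 is a limit of the assay and not a number: the limit of > 10000 nM in this assay, at which 1 of the 4 values shown sits. The ring at the end of the chain therefore matters in this read-out as well as the chain, although this single pair cannot separate the departure of the ring's hydrogen-bond donor from the entry of sulfur and a second ring nitrogen.

As far as these compounds go, it remains open whether a 1-methylpyrrol-2-yl or furan-2-yl ring on the same chain would behave like 1H-pyrrol-2-yl or like 1,3-thiazol-2-yl. From the compounds shown here alone, it is also open whether 1,3-thiazol-2-yl on the longer chain of compound 3 would give a measurable number.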